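Swapping Fluoro for Bromo on a Tetrazole Aniline Pair

This account rests on a few compounds, and the source may have more. Where it says the series, first, only, none or still open, it means among the compounds named here.

Of the compounds shown here, three that share one core have been measured in an ADME assay on V79 cells (Cricetulus griseus) for cytotoxicity, read by MTT assay, with a stated time of 72 h; on this read-out lower numbers stand for stronger inhibition and higher numbers for weaker inhibition. Compound 1, `COc1ccc(-n2nnnc2Nc2ccc(Br)cc2)cc1`, gives 212000 nM. Compound 2, `COc1ccc(-n2nnnc2Nc2ccc(F)cc2)cc1`, gives 236000 nM. The two differ in one place, (bromo in place of fluoro on an aromatic carbon), and that change made a step of a 1.1-fold lower number from compound 2 to compound 1 (0.05 log units; within the scatter). Compound 3, `COc1ccc(Nc2nnnn2-c2ccc(F)cc2)cc1`, has the same atoms as compound 2 joined differently; the difference between the two cores is not broken down here. In this assay compound 3 gives 145000 nM, which sits within the scatter of both compound 1 and compound 2, so no order among the three can be read from these numbers.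

Compound 4, `COc1ccc(Nc2nnnn2-c2ccc(Br)cc2)cc1`, has not yet been measured. It stands to compound 3 as compound 1 stands to compound 2: the change is bromo in place of fluoro on an aromatic carbon, and its place is described in the same words for both pairs, so it is the same change made on the other core. Within the data shown here, the only guide for its size is the step from compound 2 to compound 1, which stayed within the scatter. On that basis the step from compound 3 to compound 4 is expected to be small, about a 1.1-fold lower number from compound 3 to compound 4 (0.03 log units; within the scatter), in this assay. Compound 4 is therefore estimated to give about 135000 nM, with a likely range from 70000 nM to 270000 nM, resting on the value of compound 3 and on the step seen between compound 2 and compound 1.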

Compound 4, half-maximal inhibitory concentration: 125000 nM
The estimate for compound 4 lay 1.1-fold (0.03 log units) above the measured number; measured number inside the range.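

In this assay, bromo in place of fluoro on the core of compound 3 gives a small step (a 1.2-fold lower number from compound 3 to compound 4 (0.06 log units; within the scatter)), and it can be set beside the same change on the core of compound 1: the same change on two cores in this assay, a 1.1-fold lower number (0.05 log units; within the scatter) from compound 2 to compound 1 and a 1.2-fold lower number (0.06 log units; within the scatter) from compound 3 to compound 4, 1.0-fold (0.02 log units) apart, within the scatter of two such steps. For these two pairs, then, the change carries over from one core to the other in a simple sense: on both cores the swap stays within the ordinary spread of repeated measurements, and the two steps agree with each other. This does not show that bromo and fluoro truly differ in this assay, since neither step can be told apart from scatter, and two matching small steps are no test of whether a larger effect would also carry across the cores, nor of whether the agreement would hold beyond these four compounds.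

The compounds shown vary only between fluoro and bromo at this one place on the aromatic ring, so the effect of quite different groups there, such as an amine, a carboxylic acid or a longer chain, remains open. Also open, going by these compounds, is whether a group that gave a step beyond the scatter on one core would give a matching step on the other.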